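The source may hold more compounds than are shown below. What is called first, only, known or untested is meant among the compounds shown, and "the series" means these compounds.

Measured in an ADME assay on TZM cells (Homo sapiens) for cytotoxicity, with a stated time of 1 days; a higher number here means that more compound is tolerated, a lower number that less compound is tolerated:
compound 1 `CCNC(=O)c1cc(N)c(Nc2ccc(C#N)cc2)cc1Oc1c(C)cc(CCC#N)cc1C`, 105000 nM
compound 2 `Cc1cc(CCC#N)cc(C)c1Oc1cc(Nc2ccc(C#N)cc2)c(N)cc1C(=O)NC1CC1`, 121000 nM
compound 3 `Cc1cc(CCC#N)cc(C)c1Oc1cc(Nc2ccc(C#N)cc2)c(N)cc1CN(C)C`, 23800 nM

Compound 3 stands lowest of the three: a 4.4-fold lower number from compound 1 to compound 3 (0.64 log units; beyond the scatter) and a 5.1-fold lower number from compound 2 to compound 3 (0.71 log units; beyond the scatter), both beyond the scatter, whereas a 1.2-fold higher number from compound 1 to compound 2 (0.06 log units; within the scatter) stays within it. Compound 4 `Cc1cc(CCC#N)cc(C)c1Oc1cc(Nc2ccc(C#N)cc2)c(N)cc1COC(=O)C1CC1` differs from compound 3 by (cyclopropylcarbonyl)oxy in place of dimethylamino on a saturated chain carbon bound to an aromatic carbon. For the measured compounds named here, no measured step covers this exact exchange; the nearest are the two steps just named, in which the dimethylaminomethyl group enters in place of a carboxamide and the number falls. Compound 4 removes that group again, and the carbonyl and cyclopropyl it gains are elements that compounds 1 and 2 also carry. A modest rise back toward those two compounds is therefore expected, a 3.4-fold higher number from compound 3 to compound 4 (0.53 log units; beyond the scatter). For compound 4 the estimate in this assay is 80000 nM, with a range of 30000 nM to 200000 nM.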

Compound 4, half-maximal cytotoxic concentration: 42200 nM
Estimate against measurement, compound 4: 1.9-fold (0.28 log units) above, and the stated range covers the measured number.
By their numbers in this assay, from the lowest: compounds 3 and 4 (each within the scatter of the next); then compounds 1 and 2 (each within the scatter of the next).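

In this assay, (cyclopropylcarbonyl)oxy in place of dimethylamino on the saturated chain carbon gives a 1.8-fold higher number from compound 3 to compound 4 (0.25 log units; within the scatter) in this series, so compounds 3 and 4 do not separate at this position. Both a 2.9-fold lower number from compound 2 to compound 4 (0.46 log units; beyond the scatter) and a 2.5-fold lower number from compound 1 to compound 4 (0.40 log units; beyond the scatter) come with ((cyclopropylcarbonyl)oxy)methyl in place of the carboxamide on the aromatic carbon, so the lower number against compounds 1 and 2 does not require the dimethylamino group. No supporting data explain this pattern.

Open, on these data alone, is whether a simple hydroxymethyl or a carboxylic acid on that aromatic carbon would read with compounds 3 and 4 or with compounds 1 and 2.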